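The compounds below may be only part of what the source reports. "The series", "measured", "known", "first", "only" and "open" are said of these compounds alone.

In a functional assay on PC-9 cells (Homo sapiens) for inhibition, read by MTT assay, with a stated time of 48 h, tested at 10 uM (on this read-out higher numbers stand for more inhibition at the one concentration tested (going by the name of the read-out) and lower numbers for less inhibition), compound 1 `Cc1ccc(Nc2cc(NC(=O)Nc3c(Cl)cccc3Cl)ncn2)cc1F` gives 92% and compound 3 `O=C(Nc1cc(Nc2ccc(F)c(Cl)c2)ncn1)Nc1c(Cl)cccc1Cl` gives 91.1%, while compound 2 `COc1cc(NC(=O)Nc2cc(Nc3ccc(F)c(Cl)c3)ncn2)cc(OC)c1` gives 77.5%, the lowest of the three numbers, set apart beyond the scatter from both compound 3 and compound 1. Compound 4 `COc1cc(NC(=O)Nc2cc(Nc3ccc(OC)c(C)c3)ncn2)cc(OC)c1` differs from compound 2 by 4-methoxy-3-methylphenyl in place of 3-chloro-4-fluorophenyl on a nitrogen on an aromatic ring. For the measured compounds named here, only one measured step changes the group on the same nitrogen: a number 0.9 percentage points lower from compound 1 to compound 3 (within the scatter), an exchange of one aryl group for another that stayed within the scatter. Going by the values given here, no measured pair exchanges a chlorine- and fluorine-bearing aryl group for a methoxy- and methyl-bearing one, so that step offers only loose guidance. On this basis the step from compound 2 to compound 4 is expected to be a number 5.5 percentage points lower from compound 2 to compound 4 (within the scatter), within the scatter. Compound 4 is therefore estimated at 72%, with a range from 55% to 88%.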

Compound 4, a percentage reported as inhibition, at one concentration (the size of the read-out at that concentration, not a potency): 62%
Estimate against measurement, compound 4: 10 percentage points above; measured number inside the range.
By their numbers in this assay, from the lowest: compound 4; then compound 2; then compounds 3 and 1 (each within the scatter of the next).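

In this assay, for the compounds shown here, the aryl group on a nitrogen on an aromatic ring turns out to matter, with a number 15.5 percentage points lower from compound 2 to compound 4 (beyond the scatter) where the only earlier exchange at this place, a number 0.9 percentage points lower from compound 1 to compound 3 (within the scatter), had stayed within the scatter. This position is therefore not indifferent to its aryl group, at least with the other end shared by compound 2 and compound 4. Nothing at hand speaks to why the number falls. As far as these compounds go, it remains open whether losing chlorine and fluorine or gaining methoxy and methyl carries the step, and whether the exchange would cost as much with the other end of compound 3. From the compounds shown here alone, how an amine or a carboxylic acid on this aryl ring would fare is also open.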